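From an Ethyl to an Ethenyl Link on the Carbonyl

The compounds below may be only part of what the source reports. "The series", "measured", "known", "first", "only" and "open" are said of these compounds alone.

Compound 1 `O=C(CCCCCCc1cn(-c2ccccc2-c2ccccc2)nn1)NCc1cccnc1` gives 98% in a functional assay on SH-SY5Y cells (Homo sapiens) for cytotoxicity, read by MTT assay, with a stated time of 48 h, tested at 1 uM; on this read-out lower numbers stand for a stronger effect and higher numbers for a weaker effect at the one concentration tested. Compound 2 `O=C(CCc1cccnc1)NCCCCCc1cn(-c2ccccc2-c2ccccc2)nn1` gives 54% in the same read-out.

Within the data shown here, on these two numbers compound 2 stands lowest, the stronger effect; the only measured step, a number 44 percentage points lower from compound 1 to compound 2 (beyond the scatter), rearranges the chain and the amide rather than touching the link on the carbonyl. Compound 3 `O=C(/C=C/c1cccnc1)NCCCCCc1cn(-c2ccccc2-c2ccccc2)nn1` differs from compound 2 by 2-(pyridin-3-yl)ethenyl in place of 2-(pyridin-3-yl)ethyl on a carbonyl carbon. Among the measured compounds shown here, no measured step covers this kind of change, so nothing indicates a shift beyond the scatter. Compound 3 is therefore expected to stay close to compound 2, with an estimated step of a number 1 percentage points higher from compound 2 to compound 3 (within the scatter) and an estimated value of 55%, between 32% and 80%.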

Compound 3, a percentage reported as activity, at one concentration (the size of the read-out at that concentration, not a potency): 32%
The estimate for compound 3 lay 23 percentage points above the measured number; the range from low to high includes it.
By their numbers in this assay, from the lowest: compound 3; then compound 2; then compound 1.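

In this assay, 2-(pyridin-3-yl)ethenyl in place of 2-(pyridin-3-yl)ethyl on the carbonyl carbon gives a number 22 percentage points lower from compound 2 to compound 3 (beyond the scatter) and adds only a double bond outside aromatic rings, so the link itself matters at this position. With a number 66 percentage points lower from compound 1 to compound 3 (beyond the scatter) as well, compound 3 has the strongest effect of the three. The data offer no measured explanation for this change.
Going by these compounds, it remains open whether an ethynyl link on the carbonyl, or a longer chain there, would lower the number further.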